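Side Chain Variation on a Shared Terpenoid Core

The source may hold more compounds than are shown below. What is called first, only, known or untested is meant among the compounds shown, and "the series" means these compounds.

Compound 1: `C[C@H]1CC[C@@]23C1=C[C@@]1(C)CC[C@](C)(C[C@H](O)C(=O)[C@@](C)(O)CO)[C@H]1[C@@H]2CC[C@@H]3C` — 18000 nM
Compound 2: `C[C@H]1CC[C@@]23C1=C[C@@]1(C)CC[C@](C)(C[C@H](O)[C@H](O)C(C)(C)O)[C@H]1[C@@H]2CC[C@@H]3C` — 18000 nM

Among the measured compounds shown here, compound 2 stands level with compound 1 in a functional assay on cells (Panel NCI-60 (60 carcinoma cell lines), Homo sapiens) for inhibition; on this read-out lower numbers stand for stronger inhibition and higher numbers for weaker inhibition: the only measured step, no change at the digits printed from compound 1 to compound 2 (within the scatter), altered the same chain end and produced no shift beyond the scatter. Compound 3, `C[C@H]1CC[C@@]23C1=C[C@@]1(C)CC[C@](C)(C[C@H](O)[C@H](O)C4(C)CO4)[C@H]1[C@@H]2CC[C@@H]3C`, is not yet measured. It differs from compound 2 by 2-methyloxiran-2-yl in place of 1-hydroxy-1-methylethyl on a saturated chain carbon bound to an oxygen on a saturated carbon and a saturated chain carbon. For the measured compounds named here, no measured pair covers this particular exchange, so the expectation leans on the one step available: compound 1 and compound 2 sit together in this assay despite a change at the same place, and compound 2 in that assay gives 18000 nM. Compound 3 is therefore expected to remain close to compound 2, with a 1.1-fold lower number from compound 2 to compound 3 (0.05 log units; within the scatter) as the estimated step, and no movement beyond the scatter. The estimate for compound 3 in this assay is 16000 nM, within a range of 5000 nM to 45000 nM.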

Compound 3, half-maximal inhibitory concentration: 18000 nM
Compound 3: middle estimate off by 1.1-fold (0.05 log units), on the low side, and the stated range covers the measured number.
By their numbers in this assay, from the lowest: compounds 1, 2 and 3 (each within the scatter of the next).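

In this assay, replacing 1-hydroxy-1-methylethyl with 2-methyloxiran-2-yl gives no change at the digits printed from compound 2 to compound 3 (within the scatter) on a saturated chain carbon bound to an oxygen on a saturated carbon and a saturated chain carbon. This position therefore accepts an entering group with one three-membered non-aromatic ring and 0 hydrogen-bond donors in place of a group with no ring and 1 hydrogen-bond donor, a kind of change the earlier pair did not include. The wider exchange at the same place gives no change at the digits printed from compound 1 to compound 3 (within the scatter) and so leaves compound 1, compound 2 and compound 3 level at the digits printed, and no measurement is available that explains this.

Going by these compounds, it remains open whether an amine, a carboxylic acid or a longer chain at this place would also leave the number unmoved. On these data alone, it also remains open whether the shared core, rather than the chain end, sets the level seen in this assay for these compounds.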